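This account rests on a few compounds, and the source may have more. Where it says the series, first, only, none or still open, it means among the compounds named here.

Working notes on a functional assay on HeLa cells (Homo sapiens) for antiproliferative activity, read by MTT assay, with a stated time of 72 h; on this read-out higher numbers stand for weaker inhibition and lower numbers for stronger inhibition. Compound 1 `Cc1ccc2c(=O)c(CSC(=S)N(C(C)C)C(C)C)coc2c1` gives 1400 nM, the lowest of the two numbers in hand; compound 2 `O=c1c(Cl)c(CSC(=S)N2CCOCC2)oc2ccccc12` gives 4500 nM. Compound 3 `CC(C)N(C(=S)SCc1coc2cc(Cl)ccc2c1=O)C(C)C` sits at the limit of > 25000 nM in this assay, at which 1 of the 3 values shown sits; its reading of > 25000 nM is a limit rather than a number. Among the compounds with values here, the one measured step, an at least 17-fold higher number from compound 1 to compound 3 (1.25 log units; beyond the scatter), concerns the substituent on the aromatic carbon and leaves the thiocarbonyl end untouched. Compound 4 `Cc1ccc2c(=O)c(CSC(=S)N3CCCC3)coc2c1` differs from compound 1 at that thiocarbonyl carbon: pyrrolidin-1-yl in place of diisopropylamino on a thiocarbonyl carbon. Within the data shown here, no measured step bears on this change, so no shift beyond the scatter is expected, with the uncertainty spread in both directions. Compound 4 is estimated at 2000 nM, range 700 nM to 6000 nM. The expected step of a 1.4-fold higher number from compound 1 to compound 4 (0.15 log units; within the scatter) is accordingly small.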

Compound 4, half-maximal inhibitory concentration: 4400 nM
The estimate for compound 4 lay 2.2-fold (0.34 log units) below the measured number; measured number inside the range.
By their numbers in this assay, from the lowest: compound 1; then compounds 4 and 2 (each within the scatter of the next). At a limit, above all of these: compound 3.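

In this assay the thiocarbonyl end of the series is not silent: pyrrolidin-1-yl in place of diisopropylamino gives a 3.1-fold higher number from compound 1 to compound 4 (0.50 log units; beyond the scatter) with the core of compound 1 kept. The earlier step reached only the substituent on the aromatic carbon, whereas this one shows that the group on the thiocarbonyl carbon also moves the number, though modestly. Nothing in hand accounts for this shift.

Open, on these data alone, is where a piperidine ring or a diethylamino group on that thiocarbonyl carbon would fall relative to compound 1 and compound 4. Also open, as far as these compounds go, is whether an ethyl group on the aromatic carbon would keep the number of compound 1.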